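The source may report more compounds than this note shows. Statements on the series, on what has been measured and on what is new or still open speak of the compounds shown alone.

Compound 1 `CS/C(=N\C(=O)c1sccc1Cl)NC(=O)c1sccc1Cl` and compound 2 `CS/C(=N\C(=O)c1ccno1)NC(=O)c1ccno1` share a methylsulfanyl group on a carbon with a double bond to nitrogen, but their cores are built differently, and the difference between the two cores is not broken down here. In a functional assay on PC-3 cells (Homo sapiens) for cytotoxicity, read by MTT assay, with a stated time of 72 h (on this read-out lower numbers stand for stronger inhibition of growth and higher numbers for weaker inhibition of growth), compound 1 gives 57400 nM. Compound 2 reaches only the limit of this assay, > 100000 nM, which is a limit and not a number. Compound 3 `C[Se]/C(=N\C(=O)c1ccno1)NC(=O)c1ccno1` is compound 2 with a group of 2 heavy atoms (1 carbon, 1 selenium; no ring) in place of a group of 2 heavy atoms (1 carbon, 1 sulfur; no ring), on a carbon with a double bond to nitrogen; in this assay compound 3 gives 39300 nM. This step, an at least 2.5-fold lower number from compound 2 to compound 3 (0.40 log units; beyond the scatter), can only be stated as a lower bound because of the limit of > 100000 nM in this assay, at which 1 of the 3 values shown sits.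

Compound 4 `C[Se]/C(=N\C(=O)c1sccc1Cl)NC(=O)c1sccc1Cl` carries the same change on the core of compound 1: a group of 2 heavy atoms (1 carbon, 1 selenium; no ring) in place of a group of 2 heavy atoms (1 carbon, 1 sulfur; no ring), on a carbon with a double bond to nitrogen. The places of the two changes are the same word for word, so the change is the same. Because the measured step, an at least 2.5-fold lower number from compound 2 to compound 3 (0.40 log units; beyond the scatter), is an open-ended one, its true size is not known, and a single pair is a thin basis for carrying it over. The step from compound 1 to compound 4 is expected to be a 2.3-fold lower number from compound 1 to compound 4 (0.36 log units; beyond the scatter), a modest lowering in line with the bound seen. Compound 4 is therefore estimated to give 25000 nM in this assay, with a range from 10000 nM to 57000 nM.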

Compound 4, concentration for total growth inhibition: 7030 nM
Estimate against measurement, compound 4: 3.6-fold (0.55 log units) above; the whole stated range lies above it.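

In this assay, the replacement of the methylsulfanyl group by its selenium counterpart, on a carbon with a double bond to nitrogen, gives an 8.2-fold lower number from compound 1 to compound 4 (0.91 log units; beyond the scatter), so the number falls on this core as it did on the core of compound 2. Two pairs thus agree in direction, which shows that the change can carry over between these two cores, though two pairs establish no rule for the series, and the comparison of size rests on the following: the same change on two cores in this assay, an at least 2.5-fold lower number (0.40 log units; beyond the scatter) from compound 2 to compound 3 and an 8.2-fold lower number (0.91 log units; beyond the scatter) from compound 1 to compound 4; the limit leaves it open whether they differ The size of the step therefore cannot be said to carry over, or to depend on the core, because one of the two steps has no upper end: the limit of > 100000 nM in this assay, at which 1 of the 4 values shown sits.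

The compounds shown leave open what other groups would do at this carbon, such as an amine in place of the methylsulfanyl group, or a longer chain on the sulfur or the selenium. They also leave open whether the same change would lower the number on cores other than these two, and whether it would do so in any cell line other than the one used here.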